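A few compounds are considered here, and "the series" means these few. Any claim that something is new, unique, unknown or untested is made for them only; others in the source may bear on it.

Measured compounds and their values:
compound 1, `Cc1ccccc1S(=O)(=O)NC(=O)c1ccc(Nc2nc(NC3(c4ccc(Cl)cc4)CC3)nc(OCC(F)(F)F)n2)cc1`, 265 nm/s
compound 2, `CC(C)(C)NC(=O)NCCS(=O)(=O)NC(=O)c1ccc(Nc2nc(NC3(c4ccc(Cl)cc4)CC3)nc(OCC(F)(F)F)n2)cc1`, 49 nm/s
compound 3, `CC(C)C(=O)NCCS(=O)(=O)NC(=O)c1ccc(Nc2nc(NC3(c4ccc(Cl)cc4)CC3)nc(OCC(F)(F)F)n2)cc1`, 13 nm/s

The three compounds share one core and differ only in the group on the sulfonyl sulfur. In a physicochemical assay for permeability, using PAMPA, at pH 7.4 (on this read-out lower numbers stand for lower permeability and higher numbers for higher permeability), compound 1 gives 265 nm/s, compound 2 gives 49 nm/s and compound 3 gives 13 nm/s. Compound 2 thus stands second highest of the three numbers; its nearest neighbour is compound 3, with a 3.8-fold lower number from compound 2 to compound 3 (0.58 log units; beyond the scatter), and the furthest is compound 1, with a 5.4-fold lower number from compound 1 to compound 2 (0.73 log units; beyond the scatter).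

Compound 4, `CS(=O)(=O)NC(=O)c1ccc(Nc2nc(NC3(c4ccc(Cl)cc4)CC3)nc(OCC(F)(F)F)n2)cc1`, has not yet been measured in this assay. It differs from compound 2 as follows: hydrogen in place of (((tert-butyl)carbamoyl)amino)methyl on a saturated chain carbon bound to a sulfonyl sulfur.

Within the data shown here, no measured step removes this whole chain; the steps that bear on it are a 5.4-fold lower number from compound 1 to compound 2 (0.73 log units; beyond the scatter) and a 20-fold lower number from compound 1 to compound 3 (1.31 log units; beyond the scatter), where the chains bearing the urea or amide replaced the 2-methylphenyl group, and a 3.8-fold lower number from compound 2 to compound 3 (0.58 log units; beyond the scatter), which compares the two chain ends. Going back from compound 2 to a bare methyl group is therefore expected to move the number upward by a modest step, a 3.1-fold higher number from compound 2 to compound 4 (0.49 log units; beyond the scatter), though the direction of that step is only estimated. Compound 4 is expected to give about 150 nm/s, within a range of 50 nm/s to 400 nm/s.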

Compound 4, apparent permeability: 11 nm/s
Compound 4: the middle estimate sits 14-fold (1.13 log units) above what was measured; the measured number lies below the stated range.
By their numbers in this assay, from the lowest: compounds 4 and 3 (each within the scatter of the next); then compound 2; then compound 1.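

In this assay, the bare methyl group does not stand with 2-methylphenyl: replacing the 2-(((tert-butyl)carbamoyl)amino)ethyl chain with methyl gives a 4.5-fold lower number from compound 2 to compound 4 (0.65 log units; beyond the scatter), so a small group on the sulfonyl sulfur does not bring back the high number, and the tert-butyl urea chain end is the one that stands above it. The step to methyl from the isopropyl amide chain is a 1.2-fold lower number from compound 3 to compound 4 (0.07 log units; within the scatter), so these two cannot be told apart, whereas replacing 2-methylphenyl with methyl gives a 24-fold lower number from compound 1 to compound 4 (1.38 log units; beyond the scatter). Among these four compounds the high number goes only with 2-methylphenyl, and nothing given here accounts for this.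

On these data alone, it remains open whether plain phenyl would keep the number of compound 1. As far as these compounds go, it is also open where an unsubstituted propyl chain or a chain ending in a carboxylic acid would fall.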